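Phenyl for Methyl at the Far End of Compound 3

The source may report more compounds than this note shows. Statements on the series, on what has been measured and on what is new or still open speak of the compounds shown alone.

Three compounds that share an acrylonitrile-type linkage give numbers in a functional assay on MIA cells (Homo sapiens) for inhibition, read by MTT assay, with a stated time of 72 h; on this read-out higher numbers stand for weaker inhibition of growth and lower numbers for stronger inhibition of growth. Compound 1 `N#C/C(=C\c1c(F)c(F)c(F)c(F)c1F)C(=O)c1ccc[nH]1` gives 25000 nM, and compound 2 `N#C/C(=C\c1c[nH]c2ccccc12)C(=O)c1c[nH]c2ccccc12` gives 14000 nM. Compound 3 `COc1ccc(CNC(=O)/C(C#N)=C/c2ccc(C)o2)cc1` gives 51000 nM, the highest of the three: compound 1 lies nearest to it, with a gap beyond the scatter, and compound 2 lies furthest from it, also beyond the scatter. Compound 3 is thus the weakest inhibitor of growth among the three.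

Compound 4 `COc1ccc(CNC(=O)/C(C#N)=C/c2ccc(-c3ccccc3)o2)cc1` differs from compound 3 in one place, (phenyl in place of methyl on an aromatic carbon). Going by the values given here, no measured pair in this set shows this exchange, so nothing in the data fixes its size or direction. Taking the step as a modest one, the expected move from compound 3 to compound 4 is a 2.6-fold lower number from compound 3 to compound 4 (0.41 log units; beyond the scatter). Compound 4 is therefore estimated at 20000 nM in this assay, with a range from 7000 nM to 60000 nM.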

Compound 4, concentration for 50% growth inhibition: > 100000 nM
Compound 4: no number, only a limit; the forecaster's own chance of this, stated with the estimate: 10%; at least 5.0-fold (0.69 log units) between middle value and limit.
By their numbers in this assay, from the lowest: compounds 2 and 1 (each within the scatter of the next); then compound 3. At a limit, above all of these: compound 4.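

Compound 4 carries no number in this assay, only a limit of the assay: the limit of > 100000 nM in this assay, at which 1 of the 4 values shown sits. The exchange of methyl for phenyl on the aromatic carbon next to the ring oxygen reads as an at least 1.9-fold higher number from compound 3 to compound 4 (0.29 log units; that floor lies within the scatter), so phenyl at this place gave no lower number, while the true size of the step stays hidden behind the limit. The earlier compounds shown here, none of which formed a pair differing in one place, could show nothing about this position.

As far as these compounds go, it remains open whether an ethyl group, a methoxy group or an amine at this place would give a measurable number, and whether any group here would give a lower number than compound 3 does. From the compounds shown here alone, whether the same exchange would read alike on another core also remains unknown.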